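From Chloro to Diallylamino on a Saturated Chain Carbon

This account rests on a few compounds, and the source may have more. Where it says the series, first, only, none or still open, it means among the compounds named here.

Within the data shown here, in a functional assay on MGC-803 cells (Homo sapiens) for cytotoxicity, read by MTT assay, with a stated time of 48 h (a lower number here means a stronger inhibitor, a higher number a weaker inhibitor), compound 1 `CC1=NN(C(=O)CCl)C(c2cc(Br)ccc2O)C1` gives 13500 nM, the lower of the only two numbers available. Compound 3 `CCN(CC)CC(=O)N1N=C(C)CC1c1ccccc1O` gives 39800 nM, and this gap lies beyond the usual scatter. Compound 2 `CC1=NN(S(=O)(=O)c2ccc([N+](=O)[O-])cc2)C(c2cc(Cl)ccc2O)C1` is reported as "not active" (no number reported), with no number attached.

Compound 4 `C=CCN(CC=C)CC(=O)N1N=C(C)CC1c1cc(Br)ccc1O` has not yet been measured. Its structure departs from that of compound 1 by diallylamino in place of chloro on a saturated chain carbon bound to a carbonyl carbon, with diallylamino in place of chloro on a saturated chain carbon bound to a carbonyl carbon. Among the measured compounds shown here, no measured pair differs in one place only, so the expectation rests on thin evidence. For the measured compounds named here, compound 3, the one measured compound with an amino group on that chain, gives 39800 nM, the higher of the two numbers. A moderate move towards weaker inhibition in this assay is therefore expected, estimated as a 1.6-fold higher number from compound 1 to compound 4 (0.21 log units; within the scatter). For compound 4 the expected value is 22000 nM, with an estimated range from 7000 nM to 60000 nM.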

Compound 4, half-maximal inhibitory concentration: 10200 nM
The estimate for compound 4 lay 2.2-fold (0.33 log units) above the measured number, within the range that was stated.
By their numbers in this assay, from the lowest: compounds 4 and 1 (each within the scatter of the next); then compound 3.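

In this assay, among these compounds, the place on a saturated chain carbon bound to a carbonyl carbon accepts a large exchange without a separable effect: with a 1.3-fold lower number from compound 1 to compound 4 (0.12 log units; within the scatter) as the only reading, chloro and diallylamino cannot be told apart. One chlorine atom gives way to a group of 7 heavy atoms with 2 double bonds, and the number stays within the scatter, so this pair gives no sign that the chloro group is needed for the activity seen in compound 1. No measurement shown accounts for this result.

On these data alone, whether a dimethylamino or morpholino group at this place, or a longer chain carrying the diallylamino group, would move the number beyond the scatter from compound 1 remains open. No pair shown isolates the bromo group on the core, so its contribution also remains unknown.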